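The source may hold more compounds than are shown below. What is called first, only, known or untested is meant among the compounds shown, and "the series" means these compounds.

In a functional assay on HeLa cells (Homo sapiens) for antiproliferative activity, read by WST assay, with a stated time of 72 h (a higher number here means a weaker inhibitor, a lower number a stronger inhibitor), compound 1 `COC(=O)/C=C/c1ccc(NCc2ccccc2O)cc1` gives 7170 nM and compound 2 `COC(=O)/C=C/c1ccc(NCc2cc(Br)ccc2O)cc1` gives 7820 nM, so these two lie within the scatter of each other. Compound 3 `COC(=O)/C=C/c1ccc(NCc2ccc(O)c(O)c2)cc1` gives 78100 nM, a clearly higher number, which leaves compound 2 on the stronger side of this small set. Compound 4 `COC(=O)/C=C/c1ccc(NCc2cc(Br)cc(Br)c2O)cc1` changes compound 2 in one place: bromo in place of hydrogen on an aromatic carbon. The new bromo sits ortho to a hydroxy group and meta to a bromo group. For the measured compounds named here, only one measured step bears on this: the same swap, made on another carbon, gave a 1.1-fold higher number from compound 1 to compound 2 (0.04 log units; within the scatter), within the scatter. The expected change is therefore none beyond the scatter, estimated as a 1.2-fold lower number from compound 2 to compound 4 (0.08 log units; within the scatter). For compound 4 the estimated value is 6500 nM, with an expected range of 2500 nM to 17000 nM.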

Compound 4, half-maximal inhibitory concentration: 35400 nM
For compound 4 the middle estimate is 5.4-fold (0.74 log units) below the measured one; measured number outside the range, above it.
By their numbers in this assay, from the lowest: compounds 1 and 2 (each within the scatter of the next); then compound 4; then compound 3.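

In this assay, bromo in place of hydrogen on this carbon, ortho to a hydroxy group and meta to a bromo group, gives a 4.5-fold higher number from compound 2 to compound 4 (0.66 log units; beyond the scatter) and so a modestly weaker inhibitor. The same swap on another carbon gave a 1.1-fold higher number from compound 1 to compound 2 (0.04 log units; within the scatter) and stayed within the scatter, so across these two steps the outcome depends on which carbon carries the bromo. Nothing measured here explains this difference.

Going by these compounds, whether chloro, methoxy or an amine on this carbon would weaken activity to a similar extent remains open. Also open, on these data alone, is whether bromo here has the same effect without the other bromo.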